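Cytotoxicity notes: removing a methyl from compound 3

This account rests on a few compounds, and the source may have more. Where it says the series, first, only, none or still open, it means among the compounds named here.

Measured compounds in an ADME assay on MT4 cells (Homo sapiens) for cytotoxicity, read by MTT assay, with a stated time of 4 days; a lower number here means that less compound is tolerated, a higher number that more compound is tolerated:
compound 1 `COc1c(Oc2ccnc(Nc3ccc(C#N)cc3)n2)ccc2cc(C#N)ccc12` — > 211000 nM
compound 2 `Cc1cnc(Nc2ccc(C#N)cc2)nc1Oc1ccc2cc(C#N)ccc2c1Br` — > 274000 nM
compound 3 `Cc1cc(Oc2ccc3cc(C#N)ccc3c2Br)nc(Nc2ccc(C#N)cc2)n1` — > 274000 nM

None of the three values is a number; each is a limit of this assay. Compound 1 sits at the limit of > 211000 nM in this assay, at which 1 of the 3 values shown sits. Compound 2 sits at the limit of > 274000 nM in this assay, at which 2 of the 3 values shown sit. Compound 3 also sits at the same limit, so its position among the values shown is only that no half-maximal cytotoxic concentration was reached within the tested range, and no ordering of the three compounds can be read from these limits.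

Compound 4 `N#Cc1ccc(Nc2nccc(Oc3ccc4cc(C#N)ccc4c3Br)n2)cc1` is not yet measured. It differs from compound 3 in one place: hydrogen in place of methyl on an aromatic carbon. Going by the values given here, no step between measured compounds exists that would calibrate such a change. Given that compound 3 sits at the limit of > 274000 nM in this assay, at which 2 of the 3 values shown sit, no movement beyond the scatter is expected for a number no higher from compound 3 to compound 4 (the limit leaves the size open), and the result is expected most likely to be another limit. Compound 4 is estimated at 274000 nM, with a range from 100000 nM to 600000 nM.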

Compound 4, half-maximal cytotoxic concentration: 283000 nM
Beside the measured number, compound 4's estimate is 1.0-fold (0.01 log units) below it, and the stated range covers the measured number.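

In this assay, going by these compounds alone, compound 1, compound 2 and compound 3 each stand only as a limit, and no step from any of them to compound 4 can be read. The compounds shown leave open whether hydrogen in place of methyl on an aromatic carbon shifts the half-maximal cytotoxic concentration at all.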